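The compounds below may be only part of what the source reports. "The series", "measured", "known", "first", "only" and "open" are said of these compounds alone.

In an ADME assay on PC-3 cells (Homo sapiens) for cytotoxicity, read by WST assay, tested at 100 uM (on this read-out lower numbers stand for less inhibition and higher numbers for more inhibition at the one concentration tested (going by the name of the read-out)), compound 3 `O=C(Nc1ccc(Cl)cc1)C1CCCN(C(=O)c2cc(C(F)(F)F)cc(C(F)(F)F)c2)C1` gives 14%, the highest of the three numbers measured. Compound 1 `CCc1cccc(NC(=O)C2CCCN(C(=O)c3cc(C(F)(F)F)cc(C(F)(F)F)c3)C2)c1` gives 0% in this assay, and compound 2 `CC(=O)c1cccc(NC(=O)C2CCCN(C(=O)c3cc(C(F)(F)F)cc(C(F)(F)F)c3)C2)c1` gives 0%.

Two measured steps change the aryl group on the amide-type nitrogen, the same place altered in the new compound: a number 14 percentage points higher from compound 1 to compound 3 (beyond the scatter) and a number 14 percentage points higher from compound 2 to compound 3 (beyond the scatter), each a modest rise beyond the scatter. The third step swaps a group on the aromatic carbon of that aryl, and there no change at the digits printed from compound 1 to compound 2 (within the scatter).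

Compound 4 `Cn1cnnc1-c1cccc(NC(=O)C2CCCN(C(=O)c3cc(C(F)(F)F)cc(C(F)(F)F)c3)C2)c1` differs from compound 3 in one place: 3-(4-methyl-4H-1,2,4-triazol-3-yl)phenyl in place of 4-chlorophenyl on an amide-type nitrogen. Among the compounds with values here, no measured compound carries the entering group, so this change has no direct precedent. What the two relevant steps show is that exchanging the aryl on that nitrogen has moved the read-out only modestly, and the whole series sits near the bottom of the scale. A small step is therefore expected, a number 9 percentage points lower from compound 3 to compound 4 (within the scatter), most likely downward toward the numbers of compound 1 and compound 2. For compound 4 the read-out in this assay is estimated at 5%, within a range from 0% to 20%.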

Compound 4, a percentage reported as inhibition, at one concentration (the size of the read-out at that concentration, not a potency): 0%
Beside the measured number, compound 4's estimate is 5 percentage points above it; low and high end bracket the measured number.
By their numbers in this assay, from the lowest: compounds 1, 2 and 4 (each within the scatter of the next); then compound 3.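

In this assay, putting the two-ring 3-(4-methyl-4H-1,2,4-triazol-3-yl)phenyl on the amide-type nitrogen in place of 4-chlorophenyl gives a number 14 percentage points lower from compound 3 to compound 4 (beyond the scatter). The triazole also gives no change at the digits printed from compound 2 to compound 4 (within the scatter) when it replaces acetyl and no change at the digits printed from compound 1 to compound 4 (within the scatter) when it replaces ethyl, so three quite different groups on that aromatic carbon now share one number, even though the triazolyl group brings 3 hydrogen-bond acceptors and the other two compounds differ from it in size and ring content, and compound 3 alone stands apart. No measurement shown here bears on why this happens.

As far as these compounds go, whether a carboxylic acid or an amine on that aromatic carbon would also leave the number unchanged remains open. Also open, from the compounds shown here alone, is whether a bromine or fluorine in place of the chlorine of compound 3 would keep its higher number.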